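Compound 3 to compound 4: methyl to chloro

A few compounds are considered here, and "the series" means these few. Any claim that something is new, unique, unknown or untested is made for them only; others in the source may bear on it.

Measured in a functional assay on PC-12 cells (Rattus norvegicus) for cytotoxicity, read by MTT assay, with a stated time of 24 h; on this read-out lower numbers stand for an effect already at smaller amounts and higher numbers for an effect only at larger amounts of compound:
- compound 1 `Cc1c(C(=O)OCC#CCN2CCN(c3cc(C4CC4)ccc3C#N)CC2)sc2ncnc(N3CCCCC3)c12`: 16.2 ug/mL
- compound 2 `Cc1c(C(=O)OCC#CCN2CCN(c3ccc(Br)cc3C#N)CC2)sc2ncnc(N3CCCCC3)c12`: 40.9 ug/mL
- compound 3 `Cc1ccc(-c2nnc(-c3sc4ncnc(N5CCCCC5)c4c3C)o2)cc1`: 28.2 ug/mL

Not yet measured: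
- compound 4 `Cc1c(-c2nnc(-c3ccc(Cl)cc3)o2)sc2ncnc(N3CCCCC3)c12`

The value of compound 3 lies within the usual scatter of both other values, so it takes no clear place among them. The change to compound 4 is chloro in place of methyl on an aromatic carbon, para to a large group, or 4-methylphenyl to 4-chlorophenyl.

Going by the values given here, only one measured step is available, a 2.5-fold higher number from compound 1 to compound 2 (0.40 log units; beyond the scatter). It is modest and exchanges 2-cyano-5-cyclopropylphenyl for 4-bromo-2-cyanophenyl. Neither group occurs in compound 3, so this step bears on the present change only loosely. Among the compounds with values here, no measured pair compares methyl with chloro directly.

In this assay, no step beyond the scatter is therefore expected, in either direction. Compound 4 is expected at 28 ug/mL, with an estimated range from 13 ug/mL to 60 ug/mL. The expected change is a 1.0-fold lower number from compound 3 to compound 4 (0.00 log units; within the scatter).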

Compound 4, half-maximal effective concentration: 21.8 ug/mL
Estimate against measurement, compound 4: 1.3-fold (0.11 log units) above, within the range that was stated.
By their numbers in this assay, from the lowest: compounds 1, 4, 3 and 2 (each within the scatter of the next, the first and the last beyond it).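

In this assay, chloro in place of methyl on an aromatic carbon, para to a large group, gives a 1.3-fold lower number from compound 3 to compound 4 (0.11 log units; within the scatter). Going by these compounds alone, this is the first direct reading at this place, since the earlier step concerned other groups on an amine nitrogen in a ring; here the read-out does not separate 4-chlorophenyl from 4-methylphenyl. No measured property is at hand to bear on this exchange.

Open, from the compounds shown here alone, is whether a group of another kind at this place, such as an amine, a carboxylic acid or a longer chain, would move the number beyond the scatter. Also open, going by these compounds, is whether chloro and methyl stay inseparable when the same exchange is read on other parts of the shared core.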